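Carboxy in place of hydroxy on the core of compound 1

The source may hold more compounds than are shown below. What is called first, only, known or untested is meant among the compounds shown, and "the series" means these compounds.

Compound 1 `CCc1ccc2nc(C(=O)Nc3c(F)cc(-c4cccc(F)c4)cc3F)c(C)c(O)c2c1` gives 23.5% in a functional assay on Hep 3B2 cells (Homo sapiens) for antiproliferative activity, read by MTT assay, with a stated time of 24 h, tested at 1.23 ug/mL (a higher number here means a stronger effect of the compound at the concentration tested, a lower number a weaker effect), the higher of the two numbers in hand. Compound 2 `CCOc1ccc2nc(C(=O)Nc3c(F)cc(-c4cccc(F)c4)cc3F)c(C)c(O)c2c1` gives 1.03% in this assay. Going by the values given here, the only step between measured compounds is a number 22.5 percentage points lower from compound 1 to compound 2 (beyond the scatter), ethoxy in place of ethyl on an aromatic carbon, a different place from the change considered here.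

Compound 3 `CCc1ccc2nc(C(=O)Nc3c(F)cc(-c4cccc(F)c4)cc3F)c(C)c(C(=O)O)c2c1` differs from compound 1 by carboxy in place of hydroxy on an aromatic carbon. Among the compounds with values here, no measured step touches this position; the numbers in hand give no direction for the change in this assay, and the one known step does not bear on it. Compound 3 is therefore expected to give 18% in this assay, with a range from 0% to 40%. The expected step is a number 5.5 percentage points lower from compound 1 to compound 3 (within the scatter), within the scatter, with the wide range reflecting the lack of any comparable step.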

Compound 3, a percentage reported as inhibition, at one concentration (the size of the read-out at that concentration, not a potency): 4.52%
Beside the measured number, compound 3's estimate is 13.5 percentage points above it; the range from low to high includes it.
By their numbers in this assay, from the lowest: compounds 2 and 3 (each within the scatter of the next); then compound 1.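

In this assay carboxy in place of hydroxy on the aromatic carbon opposite the ring nitrogen gives a number 19 percentage points lower from compound 1 to compound 3 (beyond the scatter) and so shows that the read-out responds to a change at this position, which the earlier step did not touch. With ethyl kept on the shared core, hydroxy is the better of the two groups measured here, and this change gives the first direction for this place. No measurement in hand accounts for this drop.

On these data alone, it remains open whether the loss is peculiar to carboxy or whether other groups at this position, such as an amine, a methoxy group or a primary carboxamide, would hold the read-out of compound 1. Also open, as far as these compounds go, is whether the same change gives a similar step when ethoxy stands in place of ethyl on the core.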